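The compounds below may be only part of what the source reports. "The series", "measured", "known", "first", "only" and "open" are said of these compounds alone.

Measured compounds and their numbers:
Compound 1 `CN(C)CCN(C)CCCCOc1ccccc1/C=C/c1ccccc1` gives 0% in a functional assay on the whole organism with Mus musculus as the target, in the maximal electroshock model, at a dose of 50 mg/kg by the oral route; on this read-out higher numbers stand for more inhibition at the one dose given (going by the name of the read-out) and lower numbers for less inhibition.
Compound 2 `OCC1CCCN(CCCCOc2ccccc2/C=C/c2ccccc2)C1` gives 12.5% in the same test.
Compound 3 `COC(=O)C1CCCN(CCCCOc2ccccc2/C=C/c2ccccc2)C1` gives 0% there.

Compound 3 stands level with compound 1 at the digits given, the two together the lowest of the three numbers. Going by the values given here, its only step beyond the scatter is the one to compound 2, a number 12.5 percentage points lower from compound 2 to compound 3 (beyond the scatter), which exchanged hydroxymethyl for methoxycarbonyl on a saturated ring carbon; the other measured step, a number 12.5 percentage points higher from compound 1 to compound 2 (beyond the scatter), changed the amine on the chain.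

Compound 4 `O=C(O)C1CCCN(CCCCOc2ccccc2/C=C/c2ccccc2)C1` differs from compound 3 by hydrogen in place of methyl on an oxygen next to a carbonyl group. Neither measured step repeats this change; the closest, a number 12.5 percentage points lower from compound 2 to compound 3 (beyond the scatter), touched the same ring carbon but with a different pair of groups, and the amine step does not bear on the ester oxygen at all. Compound 3 already sits at the bottom of the read-out, so the step can only rise or stay. Among the compounds with values here, with no precedent for this exchange, a change within the scatter is expected, a number 5 percentage points higher from compound 3 to compound 4 (within the scatter). Compound 4 is therefore estimated at 5%, between 0% and 20%.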

Compound 4, a percentage reported as inhibition, in the whole organism at one dose (the size of the read-out at that dose, not a potency): 12.5%
Compound 4: middle estimate off by 7.5 percentage points, on the low side, within the range that was stated.
By their numbers in this assay, from the lowest: compounds 1 and 3 (each within the scatter of the next); then compounds 2 and 4 (each within the scatter of the next).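

On an oxygen next to a carbonyl group, hydrogen in place of methyl gives a number 12.5 percentage points higher from compound 3 to compound 4 (beyond the scatter) in this assay, so this one small exchange separates the two compounds. Going by these compounds alone, on the saturated ring carbon, carboxy and hydroxymethyl read alike, with no change at the digits printed from compound 2 to compound 4 (within the scatter), which leaves methoxycarbonyl as the one group of the three at the lower level. Replacing the amine on the chain with 3-carboxypiperidin-1-yl gives a number 12.5 percentage points higher from compound 1 to compound 4 (beyond the scatter), yet compound 3, which differs only in carrying methoxycarbonyl on that ring carbon, stands level with compound 1, so the amine exchange alone does not go with the higher number.

Nothing shown here explains these numbers. On these data alone, whether a primary amide or an ethyl ester on the same ring carbon would read with carboxy or with methoxycarbonyl stays open.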